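Working notes: a stereocentre flip on the saturated ring

The source may hold more compounds than are shown below. What is called first, only, known or untested is meant among the compounds shown, and "the series" means these compounds.

Measured in an assay on isolated protein for inhibition of eIF-2-alpha kinase GCN2 (Homo sapiens); a higher number here means a weaker inhibitor, a lower number a stronger inhibitor:
- compound 1, `CCn1cc(Nc2ncc3ccn(-c4ccc(OC)cc4)c3n2)cn1`, 405 nM
- compound 2, `COCCNC(=O)CCNc1ncc2c(Br)nn(-c3ccc4ncccc4c3)c2n1`, > 1000 nM; this value is a limit of this assay, not a number
- compound 3, `COCCNC(=O)[C@H]1CC[C@@H](Nc2ncc3c(Br)nn(-c4ccc5ncccc5c4)c3n2)C1`, 61 nM

Compound 3 has the lowest of the two numbers; its nearest neighbour is compound 1, whose number is higher, beyond the scatter. Within the data shown here, no step between measured compounds differs in a single place, so no measured step guides the next change.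

Compound 4, `COCCNC(=O)[C@@H]1CC[C@@H](Nc2ncc3c(Br)nn(-c4ccc5ncccc5c4)c3n2)C1`, is not yet measured. (the two compounds have the same atoms and bonds and differ only in configuration as drawn: 1 of 2 stereo elements differ; a stereocentre at a saturated ring carbon is drawn S in compound 3 and R in compound 4). Among the measured compounds shown here, with no stereochemical step among the measured pairs, a moderate loss is anticipated rather than a gain; the step of a 2.6-fold higher number from compound 3 to compound 4 (0.42 log units; beyond the scatter) is expected to lie somewhat beyond the scatter. Compound 4 is estimated at 160 nM, within 40 nM to 650 nM.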

Compound 4, half-maximal inhibitory concentration: 5 nM
Beside the measured number, compound 4's estimate is 32-fold (1.51 log units) above it, and the stated range ends above it.
By their numbers in this assay, from the lowest: compound 4; then compound 3; then compound 1. At a limit, above all of these: compound 2.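

In this assay, changing one saturated ring carbon from S to R gives a 12-fold lower number from compound 3 to compound 4 (1.09 log units; beyond the scatter), the first measure of how much the configuration at this position matters in the series. The step can be assigned to this stereocentre alone, and the basis for that is: the fact that compounds 3 and 4 differ only in the configuration as drawn. Going by these compounds, the second stereocentre stays the same in both compounds, so its contribution remains unknown. Also open, on these data alone, is whether the preference for R persists when a carboxylic acid or an amine replaces the methoxyethyl amide.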